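Chain length between aryl ether oxygen and phenyl

The source may hold more compounds than are shown below. What is called first, only, known or untested is meant among the compounds shown, and "the series" means these compounds.

Of the compounds shown here, three sharing one core have been measured. Compound 1 `CCCCCCCOc1cc(CCc2nc(C)c(CC)s2)nc(NCc2cc(Cl)cc(NC(=O)OC(C)C)c2)c1` gives 72 nM in an assay on cells for binding affinity to Neuropeptide Y receptor type 1 (Homo sapiens); on this read-out higher numbers stand for weaker inhibition and lower numbers for stronger inhibition. Compound 2 `CCc1sc(CCc2cc(OCc3ccccc3)cc(NCc3cc(Cl)cc(NC(=O)OC(C)C)c3)n2)nc1C` gives 237 nM, and compound 3 `CCc1sc(CCc2cc(OCCc3ccccc3)cc(NCc3cc(Cl)cc(NC(=O)OC(C)C)c3)n2)nc1C` gives 30 nM, the lowest of the three numbers and beyond the scatter from both others. Compound 4 `CCc1sc(CCc2cc(OCCCc3ccccc3)cc(NCc3cc(Cl)cc(NC(=O)OC(C)C)c3)n2)nc1C` is the next step: benzyl in place of phenyl on a saturated chain carbon, two bonds along the chain from an oxygen on an aromatic ring. Two earlier steps bear on it. Lengthening the same chain by one carbon gave a 7.9-fold lower number from compound 2 to compound 3 (0.90 log units; beyond the scatter), while a 2.4-fold lower number from compound 1 to compound 3 (0.38 log units; beyond the scatter) and a 3.3-fold higher number from compound 1 to compound 2 (0.52 log units; beyond the scatter) show that moving the phenyl along the chain changes the number in either direction. The first lengthening helped strongly, but nothing among these compounds shows that a second one will do so again, and the longer chain of compound 1 sits between the two. The step is therefore expected to be small, a 1.3-fold higher number from compound 3 to compound 4 (0.12 log units; within the scatter), with wide uncertainty. For compound 4 the estimate in this assay is 40 nM, expected to lie between 15 nM and 120 nM.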

Compound 4, half-maximal inhibitory concentration: 20 nM
Beside the measured number, compound 4's estimate is 2.0-fold (0.30 log units) above it; the range from low to high includes it.
By their numbers in this assay, from the lowest: compounds 4 and 3 (each within the scatter of the next); then compound 1; then compound 2.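

Taking phenethyloxy to 3-phenylpropoxy gives a 1.5-fold lower number from compound 3 to compound 4 (0.18 log units; within the scatter) in this assay and so shows that the sharp gain of the first lengthening does not recur with the second. For the compounds shown here, the 3-phenylpropoxy chain still holds the whole gain over the benzyl ether, with a 12-fold lower number from compound 2 to compound 4 (1.07 log units; beyond the scatter) marking the one large step in this set. It also gives a 3.6-fold lower number from compound 1 to compound 4 (0.56 log units; beyond the scatter) against the plain alkyl chain, so two of the three chains ending in phenyl, those of compound 3 and compound 4, give lower numbers than compound 1, while the benzyl ether of compound 2 goes against this.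

From the compounds shown here alone, whether a longer chain such as 4-phenylbutoxy stays at this level remains open. So does whether an amine or a carboxylic acid could take the place of the phenyl at the chain end.

No evidence here accounts for these differences.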